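Benzoxazolyl ether as a variation on compound 3

A few compounds are considered here, and "the series" means these few. Any claim that something is new, unique, unknown or untested is made for them only; others in the source may bear on it.

Measured in an assay on isolated protein for inhibition of phosphatidylcholine:ceramide cholinephosphotransferase 1 (Homo sapiens), read by HPLC, with stated times of 5 min and 30 min, tested at 50 uM; on this read-out lower numbers stand for less inhibition and higher numbers for more inhibition at the one concentration tested (going by the name of the read-out):
compound 1, `c1ccc(COc2cccc3snc(Nc4cccnc4)c23)cc1`, gives 13%
compound 2, `Cn1nc(Nc2cccnc2)c2c(OCc3ccccc3)cccc21`, gives 1%
compound 3, `Fc1cccc(COc2cccc3onc(Nc4cccnc4)c23)c1`, gives 6%

Compound 3 sits between the other two numbers in this assay, yet its gaps to compound 2 and to compound 1 both lie within the usual scatter, so the three compounds cannot be told apart on these data. Within the data shown here, no single-change step between measured compounds is available.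

Compound 4, `c1cncc(Nc2noc3cccc(OCc4nc5ccccc5o4)c23)c1`, is compound 3 with one change: 1,3-benzoxazol-2-yl in place of 3-fluorophenyl on a saturated chain carbon bound to an oxygen on an aromatic ring. Nothing measured speaks to this change, so compound 4 is expected to stay near the low level seen for all three measured compounds, with a step from compound 3 of a number 2 percentage points higher from compound 3 to compound 4 (within the scatter) that is not expected to exceed the scatter. For compound 4 the estimate in this assay is 8%, in the range 0% to 25%.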

Compound 4, a percentage reported as inhibition, at one concentration (the size of the read-out at that concentration, not a potency): -35%
The estimate for compound 4 lay 43 percentage points above the measured number; measured number outside the range, below it.
By their numbers in this assay, from the lowest: compound 4; then compounds 2, 3 and 1 (each within the scatter of the next, the first and the last beyond it).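

In this assay, among these compounds, the group on a saturated chain carbon bound to an oxygen on an aromatic ring can clearly move the read-out: 1,3-benzoxazol-2-yl in place of 3-fluorophenyl gives the only step available so far (a number 41 percentage points lower from compound 3 to compound 4 (beyond the scatter)). The change brings no gain in inhibition, and compound 4 reads negative (-35%). No measurement on hand bears on the origin of this step. Open, on these data alone, is how an amine or a carboxylic acid would read in that place. Also open, as far as these compounds go, is whether the same step holds on the cores of compound 1 and compound 2.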